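Piperidine-3-carboxamide series: cytotoxicity read-out, compound 4 pending

The source may report more compounds than this note shows. Statements on the series, on what has been measured and on what is new or still open speak of the compounds shown alone.

Measured so far:
compound 1 `O=C(Nc1cccc(N2CCCC2=O)c1)C1CCCN(C(=O)c2cc(C(F)(F)F)cc(C(F)(F)F)c2)C1` gives 0% in an ADME assay on PC-3 cells (Homo sapiens) for cytotoxicity, read by WST assay, tested at 100 uM; on this read-out lower numbers stand for less inhibition and higher numbers for more inhibition at the one concentration tested (going by the name of the read-out)
compound 2 `O=C(Nc1cccc(-c2cnco2)c1)C1CCCN(C(=O)c2cc(C(F)(F)F)cc(C(F)(F)F)c2)C1` gives 9% in this assay
compound 3 `O=C(Nc1ccc(Cl)cn1)C1CCCN(C(=O)c2cc(C(F)(F)F)cc(C(F)(F)F)c2)C1` gives 0% in this assay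

Compound 3 stands level with compound 1 at the digits shown, the two together the lowest of the three numbers; the step of no change at the digits printed from compound 1 to compound 3 (within the scatter) is flat, and the step of a number 9 percentage points lower from compound 2 to compound 3 (within the scatter) also stays within the scatter.

Compound 4 `O=C(Nc1ccc(Cl)nc1)C1CCCN(C(=O)c2cc(C(F)(F)F)cc(C(F)(F)F)c2)C1` carries the change (6-chloropyridin-3-yl in place of 5-chloropyridin-2-yl on an amide-type nitrogen). Within the data shown here, the steps that bear on it are the other swaps on the amide-type nitrogen, no change at the digits printed from compound 1 to compound 3 (within the scatter) and a number 9 percentage points lower from compound 2 to compound 3 (within the scatter), both within the scatter. The step of a number 2 percentage points higher from compound 3 to compound 4 (within the scatter) is therefore expected to stay within the scatter. Compound 4 is estimated at 2%, in the range 0% to 12%.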

Compound 4, a percentage reported as inhibition, at one concentration (the size of the read-out at that concentration, not a potency): 25%
For compound 4 the middle estimate is 23 percentage points below the measured one; the whole stated range lies below it.
By their numbers in this assay, from the lowest: compounds 1, 3 and 2 (each within the scatter of the next); then compound 4.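

In this assay, with the same atoms joined differently on the amide-type nitrogen, 6-chloropyridin-3-yl in place of 5-chloropyridin-2-yl gives a number 25 percentage points higher from compound 3 to compound 4 (beyond the scatter), so this position responds to how the chloropyridinyl group is joined and not only to the atoms it holds. Against the phenyl-bearing members the same group gives a number 16 percentage points higher from compound 2 to compound 4 (beyond the scatter) and a number 25 percentage points higher from compound 1 to compound 4 (beyond the scatter), whereas the earlier swaps here stayed within the scatter. No evidence available here bears on the reason for this difference.

As far as these compounds go, whether the step depends on the chlorine remains open. An amine or a methoxy group in its place on the pyridin-3-yl ring would address that.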